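Lengthening the Amino-Bearing Chain of Compound 3

This account rests on a few compounds, and the source may have more. Where it says the series, first, only, none or still open, it means among the compounds named here.

Compound 3 `CCCCCCCOc1ccc(CCC(N)(CC)CO)cc1` is one of three compounds tested in a functional assay on the whole organism (spleen, spleen) with Rattus norvegicus as the target; a lower number here means that less compound is needed, a higher number that more compound is needed for the effect. In this assay compound 3 gives 0.059 mg/kg. Compound 1 `CCCCCCCOc1ccc(CCC(N)(CO)CO)cc1` gives 0.049 mg/kg in this assay. Compound 2 `CCCCCCCCc1ccc(CCC(N)(CO)C(=O)O)cc1` reaches only the limit of > 10 mg/kg in this assay, so no number is known for it. Of the two numbers shown, compound 3 and compound 1 stand together, the step between them being a 1.2-fold higher number from compound 1 to compound 3 (0.08 log units; within the scatter).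

Compound 4 `CCCCCCCOc1ccc(CC[C@](N)(CO)CCC)cc1` has not yet been measured. It differs from compound 3 by a group of 7 heavy atoms (5 carbon, 1 nitrogen, 1 oxygen; no ring) in place of a group of 6 heavy atoms (4 carbon, 1 nitrogen, 1 oxygen; no ring), on a saturated chain carbon, two bonds along the chain from an aromatic carbon. Among the measured compounds shown here, the only measured step that touches this part of the molecule is a 1.2-fold higher number from compound 1 to compound 3 (0.08 log units; within the scatter), where one small group was swapped for another without leaving the scatter. A somewhat larger group at the same kind of place is therefore expected to move the number little, if at all. Compound 4 is expected to give 0.07 mg/kg, with a range from 0.025 mg/kg to 0.2 mg/kg, in this assay. The expected step is a 1.2-fold higher number from compound 3 to compound 4 (0.07 log units; within the scatter), which would stay within the scatter.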

Compound 4, dose for 50% inhibition: > 10 mg/kg
Compound 4: no number, only a limit; the forecaster's own chance of this, stated with the estimate: 5%; at least 140-fold (2.15 log units) between middle value and limit.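

Where the swap from compound 1 to compound 3 left this assay within the scatter, with a 1.2-fold higher number from compound 1 to compound 3 (0.08 log units; within the scatter), this place on the saturated chain carbon now proves far from indifferent to what sits there. Introducing the 1-amino-1-(hydroxymethyl)butyl group brings an at least 160-fold higher number from compound 3 to compound 4 (2.22 log units; beyond the scatter), and measured against the group of compound 1 it brings an at least 200-fold higher number from compound 1 to compound 4 (2.30 log units; beyond the scatter), so a small growth of the group can separate a compound given at low doses from one that reaches no number. Compound 4 yields only a limit, and it shares that limit with one other compound: the limit of > 10 mg/kg in this assay, at which 2 of the 4 values shown sit.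

As far as these compounds go, it remains open whether the longer chain or the defined stereocentre, which the group in compound 3 does not carry, accounts for the loss. The opposite stereoisomer of compound 4, and a pentyl chain in the same place, would be needed to separate the two.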